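Amide aryl swap on a pyridinylmethyl core

A few compounds are considered here, and "the series" means these few. Any claim that something is new, unique, unknown or untested is made for them only; others in the source may bear on it.

Compound 1 `O=C(CN1CCN(c2nnc(Cc3ccccc3)c3ccccc23)CC1)Nc1c(F)cccc1F` and compound 2 `O=C(CN1CCN(c2nnc(Cc3ccccc3)c3ccccc23)CC1)Nc1cc(C(F)(F)F)ccc1Cl` share one core; in a functional assay on A549 cells (Homo sapiens) for cytotoxicity, read by MTT assay, with a stated time of 72 h (on this read-out lower numbers stand for stronger inhibition and higher numbers for weaker inhibition), compound 1 gives 84500 nM and compound 2 gives 89000 nM. The change between them, (2,6-difluorophenyl in place of 2-chloro-5-(trifluoromethyl)phenyl on an amide-type nitrogen), made a 1.1-fold lower number from compound 2 to compound 1 (0.02 log units; within the scatter). Compound 3 `O=C(CN1CCN(c2nnc(Cc3ccncc3)c3ccccc23)CC1)Nc1cc(C(F)(F)F)ccc1Cl` differs from compound 2 by pyridin-4-yl in place of phenyl on a saturated chain carbon bound to an aromatic carbon, and in this assay compound 3 gives 1850 nM, a move of a 48-fold lower number from compound 2 to compound 3 (1.68 log units; beyond the scatter). Compound 4 `O=C(CN1CCN(c2nnc(Cc3ccncc3)c3ccccc23)CC1)Nc1c(F)cccc1F` carries the same change relative to compound 3, (2,6-difluorophenyl in place of 2-chloro-5-(trifluoromethyl)phenyl on an amide-type nitrogen), at the same place as the change from compound 2 to compound 1; the two cores differ by pyridin-4-yl in place of phenyl on a saturated chain carbon bound to an aromatic carbon. Because the earlier step was a 1.1-fold lower number from compound 2 to compound 1 (0.02 log units; within the scatter), the step from compound 3 to compound 4 is expected to be a 1.0-fold higher number from compound 3 to compound 4 (0.01 log units; within the scatter), resting on a single precedent. Compound 4 is therefore estimated at 1900 nM, with a range of 900 nM to 4200 nM.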

Compound 4, half-maximal inhibitory concentration: 54400 nM
Compound 4: the middle estimate sits 29-fold (1.46 log units) below what was measured; measured number above the stated range.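

The new step of a 29-fold higher number from compound 3 to compound 4 (1.47 log units; beyond the scatter) stands beside a 1.6-fold lower number from compound 1 to compound 4 (0.19 log units; within the scatter), and in this assay the aryl swap on the amide-type nitrogen does not carry from one core to the other: the same change on two cores in this assay, a 1.1-fold lower number (0.02 log units; within the scatter) from compound 2 to compound 1 and a 29-fold higher number (1.47 log units; beyond the scatter) from compound 3 to compound 4, 31-fold (1.49 log units) apart, beyond the scatter of two such steps.
The pyridin-4-yl for phenyl change depends just as much on the amide aryl group: the same change on two cores in this assay, a 48-fold lower number (1.68 log units; beyond the scatter) from compound 2 to compound 3 and a 1.6-fold lower number (0.19 log units; within the scatter) from compound 1 to compound 4, 31-fold (1.49 log units) apart, beyond the scatter of two such steps.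
Across these four compounds, the low number belongs only to the pairing in compound 3; this shows that the two changes are not additive here, but not why, nor whether this holds for any other amide aryl group.

As far as these compounds go, it remains open which part of the 2-chloro-5-(trifluoromethyl)phenyl group goes with that low number. A plain phenyl or a chlorophenyl on the amide-type nitrogen of the pyridin-4-yl core would bear on this.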